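This account rests on a few compounds, and the source may have more. Where it says the series, first, only, none or still open, it means among the compounds named here.

In an assay on isolated protein for displacement of a labelled ligand from metabotropic glutamate receptor 5 (Homo sapiens), with a stated time of 60 min, tested at 1 uM (a lower number here means less inhibition, a higher number more inhibition at the concentration tested (going by the name of the read-out)), compound 1 `COc1ccc2ncc(S(=O)(=O)c3ccc(Cl)cc3)c(N3CCC(C)CC3)c2c1` gives 91%, while compound 2 `COc1ccc2ncc(S(=O)(=O)c3ccc(Cl)c(Cl)c3)c(N3CCC(C)CC3)c2c1` gives 87%; compound 2 thus holds the lower of the two numbers shown, but the gap, a number 4 percentage points lower from compound 1 to compound 2 (within the scatter), sits within the scatter. Compound 3 `COc1ccc2ncc(S(=O)(=O)c3ccc(C)cc3)c(N3CCC(C)CC3)c2c1` carries 4-methylphenyl in place of 3,4-dichlorophenyl on a sulfonyl sulfur. Within the data shown here, the only measured step touching this part of the molecule is the one already described, and it stayed within the scatter, so no step beyond the scatter is expected in this assay; the expected change is a number 2 percentage points lower from compound 2 to compound 3 (within the scatter). Compound 3 is therefore estimated at 85%, within a range of 65% to 95%.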

Compound 3, a percentage reported as inhibition, at one concentration (the size of the read-out at that concentration, not a potency): 90%
For compound 3 the middle estimate is 5 percentage points below the measured one; low and high end bracket the measured number.
By their numbers in this assay, from the lowest: compounds 2, 3 and 1 (each within the scatter of the next).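

In this assay, 4-methylphenyl in place of 3,4-dichlorophenyl on the sulfonyl sulfur gives a number 3 percentage points higher from compound 2 to compound 3 (within the scatter), and methyl in place of chloro on an aromatic carbon gives a number 1 percentage points lower from compound 1 to compound 3 (within the scatter), so a methyl group now joins the chloro groups with no step beyond the scatter. The earlier compounds shown here showed only an added chloro group at this ring. No measured evidence explains why these groups read alike. From the compounds shown here alone, whether a carboxylic acid or an amine in place of the methyl would fit this picture stays open. Going by these compounds, all three compounds share everything outside this aromatic ring, so the contribution of those other parts also stays open.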